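A nitro for a methyl on compound 2

The source may hold more compounds than are shown below. What is called first, only, known or untested is meant among the compounds shown, and "the series" means these compounds.

Compound 1 `CCOC(=O)c1nn(-c2ccc(Cl)cc2)c(-c2ccc([N+](=O)[O-])cc2)c1CNC(C)(C)C` gives 316000 nM; 51200 nM (2 entries) in a functional assay on 786-0 cells (Homo sapiens) for inhibition, read by sulforhodamine B assay, with a stated time of 48 h (on this read-out lower numbers stand for stronger inhibition of growth and higher numbers for weaker inhibition of growth), across two entries. Compound 2 `Cc1ccc(-c2c(CNC(C)(C)C)c(C(=O)O)nn2-c2ccc(Cl)cc2)cc1` shows only a limit of > 629000 nM in this assay and no number. Compound 3 `CC(C)(C)NCc1c(C(=O)O)nn(-c2ccc(Cl)cc2)c1-c1ccc([N+](=O)[O-])cc1` differs from compound 2 by nitro in place of methyl on an aromatic carbon para to a large group. For the measured compounds named here, no measured step gauges this change, so only a modest move towards stronger inhibition is expected, with compound 1 at 316000 nM; 51200 nM (2 entries) as the sole numerical guide. The expected change is an at least 1.3-fold lower number from compound 2 to compound 3 (0.14 log units; that floor lies within the scatter) in this assay and may not clear the scatter. Compound 3 is estimated at 450000 nM with an expected range from 130000 nM to 1000000 nM in this measurement.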

Compound 3, concentration for 50% growth inhibition: 104000 nM
Estimate against measurement, compound 3: 4.3-fold (0.64 log units) above; measured number below the stated range.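

In this assay, for the compounds shown here, the change from 4-methylphenyl to 4-nitrophenyl gives the first gauged step at this position, an at least 6.0-fold lower number from compound 2 to compound 3 (0.78 log units; beyond the scatter), so growth inhibition responds to this swap. That step is only a floor, since one end of it is a limit: the limit of > 629000 nM in this assay, at which 1 of the 3 values shown sits. Compound 3 gives 104000 nM, which lies between the two entries of compound 1, 316000 nM; 51200 nM (2 entries).

The compounds shown leave open whether another group at this place, such as an amine or a nitrile, would shift the number further. They also leave open how large the step truly is.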